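The source may report more compounds than this note shows. Statements on the series, on what has been measured and on what is new or still open speak of the compounds shown alone.

In a functional assay on SMMC-7721 cells (Homo sapiens) for inhibition, read by CCK-8 assay, with a stated time of 72 h, tested at 2 uM (a higher number here means more inhibition of growth at the concentration tested, a lower number less inhibition of growth), compound 3 `Cc1ccc(SCc2ccc(C(=O)Nc3ccccc3N)cc2)cc1` gives 25.1%. That sits within the scatter of both other measured compounds: compound 1 `COc1ccc(SCc2ccc(C(=O)Nc3ccccc3N)cc2)cc1` gives 33.1% and compound 2 `Nc1ccccc1NC(=O)c1ccc(CSc2cccc(F)c2)cc1` gives 18.6%. Compound 4 `CC(C)(C)c1ccc(SCc2ccc(C(=O)Nc3ccccc3N)cc2)cc1` differs from compound 3 by one change: tert-butyl in place of methyl on an aromatic carbon. Two measured steps also change the group on this same aromatic ring, a number 8 percentage points lower from compound 1 to compound 3 (within the scatter) and a number 6.5 percentage points higher from compound 2 to compound 3 (within the scatter), and both are small. The third, a number 14.5 percentage points lower from compound 1 to compound 2 (beyond the scatter), is modest. None of them involves a tert-butyl group, so the direction is uncertain. The expected step is a number 2.1 percentage points lower from compound 3 to compound 4 (within the scatter), estimated to stay within the scatter. Compound 4 is estimated at 23%, with an expected range from 10% to 38%.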

Compound 4, percent growth inhibition at one concentration: 23.6%
For compound 4 the middle estimate is 0.6 percentage points below the measured one; measured number inside the range.
By their numbers in this assay, from the lowest: compounds 2, 4, 3 and 1 (each within the scatter of the next, the first and the last beyond it).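

Replacing the methyl with tert-butyl, which raises the group from 1 heavy atom to 4 heavy atoms, gives a number 1.5 percentage points lower from compound 3 to compound 4 (within the scatter) in this assay at this carbon, para to a large group. Much more carbon can therefore sit here without a reading that can be told apart from the methyl one. Tert-butyl also gives a number 9.5 percentage points lower from compound 1 to compound 4 (within the scatter) when it replaces methoxy, so these two groups cannot be told apart here either. Going by these compounds, whether an amine or a carboxylic acid here would read differently stays open. Nothing measured explains why these groups read alike.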